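Solubility shift on the aryl group of a fused bicyclic amine

The source may report more compounds than this note shows. Statements on the series, on what has been measured and on what is new or still open speak of the compounds shown alone.

Measured compounds:
compound 1 `COc1ccc(-c2cnn3c(NCc4ccccn4)cc(C)nc23)cc1`: < 5000 nM
compound 2 `Cc1cc(NCc2ccccn2)n2ncc(-c3ccn(C)n3)c2n1`: 188000 nM

For the measured compounds named here, in a physicochemical assay for solubility, read by HPLC, using the shake flask method, measured as kinetic solubility, with a stated time of 2 h, at pH 7.4 (a higher number here means a more soluble compound, a lower number a less soluble compound), compound 2 gives 188000 nM, the only numeric value among the two measured compounds. For compound 1 the assay returns only a limit, < 5000 nM, rather than a number (the limit of < 5000 nM in this assay, at which 1 of the 2 values shown sits). Going by the values given here, the one measured step, an at least 37-fold higher number from compound 1 to compound 2 (1.57 log units; beyond the scatter), is therefore large but open-ended at its lower side.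

Compound 3 `Cc1cc(NCc2ccccn2)n2ncc(-c3cccc(N)c3)c2n1` has not yet been measured in this assay. It differs from compound 2 by 3-aminophenyl in place of 1-methyl-1H-pyrazol-3-yl on an aromatic carbon. The change runs in the opposite sense to the measured step: a six-membered carbon-only ring comes back in at the same aromatic carbon where the step from compound 1 to compound 2 had removed one, though the entering 3-aminophenyl carries one hydrogen-bond donor and one acceptor where 4-methoxyphenyl had none and one. On that basis a step downward is expected for compound 3, smaller than the measured one, as a 4.7-fold lower number from compound 2 to compound 3 (0.67 log units; beyond the scatter). Compound 3 is accordingly estimated at 40000 nM, within a range from 8000 nM to 150000 nM.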

Compound 3, solubility: 160000 nM
Compound 3: middle estimate off by 4.0-fold (0.60 log units), on the low side; measured number outside the range, above it.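

At this aromatic carbon, this assay gives a 1.2-fold lower number from compound 2 to compound 3 (0.07 log units; within the scatter), so 3-aminophenyl and 1-methyl-1H-pyrazol-3-yl cannot be told apart in this read-out. The earlier step alone left open whether a six-membered aromatic ring of carbon only at this position goes with a low reading, but compound 3 carries such a ring, as compound 1 does, and the pair still shows an at least 32-fold higher number from compound 1 to compound 3 (1.50 log units; beyond the scatter), so ring type alone does not set the reading among these compounds. From the compounds shown here alone, that step remains open-ended, as compound 1 gives < 5000 nM, which is a limit and not a number: the limit of < 5000 nM in this assay, at which 1 of the 3 values shown sits.

The two six-membered rings differ both in their substituent and in where it sits, so the compounds shown do not separate the amine from its place on the ring. An unsubstituted phenyl, a 4-aminophenyl or a 3-methoxyphenyl at the same carbon would divide those two changes, and a pyrazole without its methyl group would likewise test how much the five-membered ring's substitution matters.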